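The compounds below may be only part of what the source reports. "The series", "measured", "known", "first", "only" and "open" are said of these compounds alone.

Measured compounds:
- compound 2 `COc1cc(-c2nn(-c3cccc(NC(=O)Nc4ccc(Cl)c(C(F)(F)F)c4)c3)cc2-c2ccncc2)ccc1Cl` — 840 nM in a functional assay on SF-295 cells (Homo sapiens) for inhibition, read by sulforhodamine B assay, with a stated time of 48 h; on this read-out higher numbers stand for weaker inhibition and lower numbers for stronger inhibition
- compound 1 `O=C(Nc1cccc(-n2cc(-c3ccncc3)c(-c3ccc(Cl)c(O)c3)n2)c1)Nc1ccc(Cl)c(Cl)c1` — "not determined" (no result reported) in this assay

Among the compounds with values here, compound 2 carries the only number in this assay; compound 1 stands beside it without a result. Compound 3 `O=C(Nc1cccc(-n2cc(-c3ccncc3)c(-c3ccc(Cl)c(O)c3)n2)c1)Nc1ccc(Cl)c(C(F)(F)F)c1` follows from compound 2 by hydrogen in place of methyl on an oxygen on an aromatic ring. Within the data shown here, no step between measured compounds is available to gauge this change, so the expected step from compound 2 to compound 3 in this assay is a 1.1-fold higher number from compound 2 to compound 3 (0.03 log units; within the scatter), not beyond the usual scatter in either direction. Compound 3 is therefore estimated at 900 nM, with a range of 350 nM to 2500 nM.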

Compound 3, half-maximal inhibitory concentration: 740 nM
Compound 3: the middle estimate sits 1.2-fold (0.09 log units) above what was measured; low and high end bracket the measured number.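

Going from methoxy to hydroxy on the aromatic ring gives a 1.1-fold lower number from compound 2 to compound 3 (0.06 log units; within the scatter) in this assay and stays within the scatter. Within the data shown here, this pair gives the first reading at this position, and the two groups are not separated here. No measurement shown bears on the reason for this.

As far as these compounds go, whether an amine or a longer chain such as ethoxy in this place would also stay within the scatter remains open. Compound 1 gives "not determined" (no result reported) and so allows no comparison with compound 3 .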